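Side chain swap from compound 3 to compound 4

A few compounds are considered here, and "the series" means these few. Any claim that something is new, unique, unknown or untested is made for them only; others in the source may bear on it.

Measured so far in an ADME assay on HEK293-A cells (Homo sapiens) for cytotoxicity, read by MTT assay, with a stated time of 48 h; a lower number here means a stronger inhibitor, a higher number a weaker inhibitor
compound 1 `CCN1CCN(C[C@H]2CN(c3ccc(-n4cc(-c5ccccn5)cn4)c(F)c3)C(=O)O2)CC1` gives 99 ug/mL as a number
compound 2 `CC(=O)OC[C@H]1CN(c2ccc(-n3cc(-c4ccccn4)cn3)c(F)c2)C(=O)O1` gives > 400 ug/mL as a limit
compound 3 `O=C1O[C@@H](Cn2ccnc2)CN1c1ccc(-n2cc(-c3ccccn3)cn2)c(F)c1` gives > 400 ug/mL as a limit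

Compound 3 has no number, only the limit > 400 ug/mL in this assay as its reading. Compound 2 and compound 3 stand together at the limit of > 400 ug/mL in this assay, at which 2 of the 3 values shown sit, and only compound 1 has a number.

Compound 4 `CS(=O)(=O)NC[C@H]1CN(c2ccc(-n3cc(-c4ccccn4)cn3)c(F)c2)C(=O)O1` carries methanesulfonamido in place of 1H-imidazol-1-yl on a saturated chain carbon bound to a saturated ring carbon.

At this same place, replacing 4-ethylpiperazin-1-yl gave an at least 4.0-fold higher number from compound 1 to compound 2 (0.60 log units; beyond the scatter) and an at least 4.0-fold higher number from compound 1 to compound 3 (0.60 log units; beyond the scatter) while putting 1H-imidazol-1-yl in place of acetoxy gave a step that the two limits leave unreadable from compound 2 to compound 3 with no size to carry over.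

Resting on an at least 4.0-fold higher number from compound 1 to compound 3 (0.60 log units; beyond the scatter) and on the absence of 4-ethylpiperazin-1-yl from compound 4 as well, the expected step is a number no higher from compound 3 to compound 4 (the limit leaves the size open) with nothing beyond the scatter and another limit likely.

For compound 4 the estimate is 400 ug/mL with an expected range from 180 ug/mL to 800 ug/mL as the likely span.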

Compound 4, half-maximal inhibitory concentration: 314 ug/mL
Beside the measured number, compound 4's estimate is 1.3-fold (0.11 log units) above it; low and high end bracket the measured number.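

In this assay, methanesulfonamido gives the one replacement for 4-ethylpiperazin-1-yl at this place whose size can be read, as a 3.2-fold higher number from compound 1 to compound 4 (0.50 log units; beyond the scatter) and not merely a limit, which is all that compound 2 and compound 3 allow. Against those two compounds, methanesulfonamido shows an at least 1.2-fold lower number from compound 3 to compound 4 (0.10 log units; that floor lies within the scatter) and an at least 1.2-fold lower number from compound 2 to compound 4 (0.10 log units; that floor lies within the scatter) and neither floor separates it from 1H-imidazol-1-yl or acetoxy. Compound 4 therefore adds a number at the weak end of the series, while the readings at this place still gather at the ceiling: the limit of > 400 ug/mL in this assay, at which 2 of the 4 values shown sit.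

From the compounds shown here alone, how far compound 2 and compound 3 lie past their limits stays open, and the step between them cannot be read. Going by these compounds, whether a simple primary amine, a carboxylic acid or a longer chain at this place would read closer to compound 1 or to compound 4 also stays open.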